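The compounds below may be only part of what the source reports. "The series", "measured", "known", "first", "only" and "open" are said of these compounds alone.

In a functional assay on HeLa cells (Homo sapiens) for antiproliferative activity, read by MTT assay, with a stated time of 48 h (on this read-out higher numbers stand for weaker inhibition and lower numbers for stronger inhibition), compound 1 `CCn1c(N)c(-c2nc3ccccc3[nH]2)c2nc(C#N)c(C#N)nc21` gives > 50000 nM, which is a limit of the assay and not a number. For the measured compounds named here, compound 2 `N#Cc1nc2c(-c3nc4ccccc4[nH]3)c(N)n(CCCN3CCCCC3)c2nc1C#N` gives 6680 nM, the only actual number so far. Compound 3 `CCN(CC)CCCCn1c(N)c(-c2nc3ccccc3[nH]2)c2nc(C#N)c(C#N)nc21` differs from it as follows: (diethylamino)methyl in place of piperidin-1-yl on a saturated chain carbon, three bonds along the chain from an aromatic nitrogen. This places (diethylamino)methyl in place of piperidin-1-yl on a saturated chain carbon, three bonds along the chain from an aromatic nitrogen; the same difference reads 3-(piperidin-1-yl)propyl to 4-(diethylamino)butyl. Going by the values given here, the one measured step that bears on this is an at least 7.4-fold lower number from compound 1 to compound 2 (0.87 log units; beyond the scatter), beyond the scatter, and its size rests on (the limit of > 50000 nM in this assay, at which 1 of the 2 values shown sits). That step introduced the amino chain, which compound 3 keeps in altered form, so only a small shift is expected. The estimated step is a 1.3-fold lower number from compound 2 to compound 3 (0.13 log units; within the scatter), not expected to exceed the scatter. For compound 3 the expected value is 5000 nM, with an estimated range of 2000 nM to 14000 nM.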

Compound 3, half-maximal inhibitory concentration: 10100 nM
For compound 3 the middle estimate is 2.0-fold (0.31 log units) below the measured one, and the stated range covers the measured number.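

In this assay, a 1.5-fold higher number from compound 2 to compound 3 (0.18 log units; within the scatter), so replacing 3-(piperidin-1-yl)propyl with the ring-free 4-(diethylamino)butyl leaves the two compounds within the scatter of each other. Compound 3 also shows that the difference from the ethyl group of compound 1 is not confined to the piperidine-bearing chain, with an at least 4.9-fold lower number from compound 1 to compound 3 (0.69 log units; beyond the scatter). That step gives only a bound on the size of the difference, not a measured size: the limit of > 50000 nM in this assay, at which 1 of the 3 values shown sits.

As far as these compounds go, the step from compound 2 to compound 3 alters the chain length and the terminal amine together, so their separate contributions remain open; 3-(diethylamino)propyl on the same aromatic nitrogen would separate them. Also open, from the compounds shown here alone, is how a terminal carboxylic acid or a morpholin-4-yl group on such a chain would compare with the terminal amines of compound 2 and compound 3.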